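The source may hold more compounds than are shown below. What is called first, only, known or untested is meant among the compounds shown, and "the series" means these compounds.

Compound 1 `Clc1ncnc2ncn(Cc3ccccc3)c12`: 6%
Compound 2 `Fc1ccc(Cn2cnc3ncnc(Cl)c32)cc1`: 7%
Compound 3 `c1ccc(Cn2cnc3c(Sc4ccccc4)ncnc32)cc1`: 1%

All three compounds were tested in an assay on isolated protein for inhibition of Rho-associated protein kinase 1 (Homo sapiens), tested at 30 uM; a lower number here means less inhibition, a higher number more inhibition at the concentration tested (going by the name of the read-out). Compound 1 gives 6% in this assay. Compound 2 gives 7%. Compound 3 gives 1%. None of the three reaches a large read-out, and the three numbers lie within the usual scatter of one another.

Compound 2 differs from compound 1 in one place only: fluoro in place of hydrogen on an aromatic carbon. This change gives a number 1 percentage points higher from compound 1 to compound 2 (within the scatter). Compound 3 has a different core from compound 1; the difference between the two cores is not broken down here.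

Compound 4 `Fc1ccc(Sc2ncnc3c2ncn3Cc2ccccc2)cc1` has not yet been measured in this assay. It stands to compound 3 as compound 2 stands to compound 1, carrying the same change: fluoro in place of hydrogen on an aromatic carbon. Going by the values given here, the step from compound 3 to compound 4 is expected to be a number 2 percentage points higher from compound 3 to compound 4 (within the scatter) because the one measured example of this change gave a number 1 percentage points higher from compound 1 to compound 2 (within the scatter). Compound 4 is therefore estimated to give about 3%, most likely between -6% and 12%.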

Compound 4, a percentage reported as inhibition, at one concentration (the size of the read-out at that concentration, not a potency): 5%
Beside the measured number, compound 4's estimate is 2 percentage points below it; the measured number falls inside the stated range.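

Fluoro in place of hydrogen, turning phenylsulfanyl into (4-fluorophenyl)sulfanyl, gives a number 4 percentage points higher from compound 3 to compound 4 (within the scatter) in this assay. Set beside the earlier step, the change reads alike on the two cores, with no difference that can be told from the scatter: the same change on two cores in this assay, a number 1 percentage points higher (within the scatter) from compound 1 to compound 2 and a number 4 percentage points higher (within the scatter) from compound 3 to compound 4, 3 percentage points apart, within the scatter of two such steps. This shows that, in these two pairs, adding the fluoro leaves the read-out within the scatter whichever core carries it, but it does not show that fluoro has no effect on other cores, or in compounds with a much larger read-out, and two small steps are too few to make a rule.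

The compounds shown leave open whether a different group on the core, such as an amine or a carboxylic acid in place of the chloro or the phenylsulfanyl group, would move the read-out beyond the scatter. They also leave open whether a longer chain in place of the benzyl group would do so.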